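Compound 2 to compound 4: a change on the carbonyl carbon

A few compounds are considered here, and "the series" means these few. Any claim that something is new, unique, unknown or untested is made for them only; others in the source may bear on it.

In an ADME assay on HepG2 2.2.15 cells (Homo sapiens) for cytotoxicity, read by MTT assay (a higher number here means that more compound is tolerated, a lower number that less compound is tolerated), compound 2 `C=C1CC[C@@H]2[C@](C)(CO)[C@H](OC(=O)/C=C/c3ccccc3)CC[C@@]2(C)[C@@H]1C/C=C1\C=COC1=O` gives 179000 nM as its half-maximal cytotoxic concentration. Compound 3 `C=C1CC[C@@H]2[C@](C)(CO)[C@H](OC(=O)/C=C/c3cc(OC)c(OC)c(OC)c3)CC[C@@]2(C)[C@@H]1C/C=C1\C=COC1=O` gives 211000 nM and lies within the scatter of compound 2. Compound 1 `C=C1CC[C@@H]2[C@](C)(COC(=O)c3ccc(OC)nc3)[C@H](O)CC[C@@]2(C)[C@@H]1/C=C/C1=CCOC1=O` gives 1340000 nM and lies beyond the scatter of compound 2, with the higher number.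

Compound 4 `C=C1CC[C@@H]2[C@](C)(CO)[C@H](OC(=O)c3ccccc3)CC[C@@]2(C)[C@@H]1C/C=C1\C=COC1=O` departs from compound 2 in one place, phenyl in place of 2-phenylethenyl on a carbonyl carbon, with phenyl in place of 2-phenylethenyl on a carbonyl carbon as the count of that difference.

Within the data shown here, the one measured step in this part of the series is a 1.2-fold higher number from compound 2 to compound 3 (0.07 log units; within the scatter) and it is small, but it alters the aromatic ring and leaves 2-phenylethenyl's double bond in place. Among the measured compounds shown here, no measured step removes that double bond, so the evidence is indirect. On that basis no step beyond the scatter is expected in this assay and the estimated step is a 1.2-fold higher number from compound 2 to compound 4 (0.09 log units; within the scatter) with no firm direction. For compound 4 the estimate is 220000 nM with an expected range from 90000 nM to 550000 nM around it.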

Compound 4, half-maximal cytotoxic concentration: 103000 nM
The estimate for compound 4 lay 2.1-fold (0.33 log units) above the measured number; low and high end bracket the measured number.
By their numbers in this assay, from the lowest: compounds 4, 2 and 3 (each within the scatter of the next, the first and the last beyond it); then compound 1.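

In this assay, among these compounds, phenyl in place of 2-phenylethenyl on the carbonyl carbon gives a 1.7-fold lower number from compound 2 to compound 4 (0.24 log units; within the scatter) and is the first measured change to remove the double bond outside the aromatic ring at this position. Alongside a 1.2-fold higher number from compound 2 to compound 3 (0.07 log units; within the scatter) for a change to the aromatic ring itself, it shows that neither measured change on this side of the ester moves the number beyond the scatter. No measurement bears on why this step is small.

This single step removes the double bond and shortens the group together, so 2-phenylethyl on the same carbonyl carbon would be needed to separate the two. As far as these compounds go, whether an amine or a carboxylic acid on the phenyl ring would leave the number within the scatter also remains open.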